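Phenyl in place of hydrogen: compound 2 to compound 4

The source may hold more compounds than are shown below. What is called first, only, known or untested is meant among the compounds shown, and "the series" means these compounds.

Measured so far:
compound 1 `Cc1c(Br)cc(C(=O)NC2CCNCC2)c(=O)n1Cc1ccc(F)cc1` — > 10000 nM, a limit of the assay
compound 2 `Cc1ccc(C(=O)NC2CCCCCC2)c(=O)n1Cc1ccc(F)cc1` — > 10000 nM, a limit of the assay
compound 3 `CC(=O)N[C@@H]1[C@@H](O)[C@H](O)[C@@H](CO)O[C@H]1NC(=O)c1cc(Br)c(C)n(Cc2ccc(F)cc2)c1=O` — > 10000 nM, a limit of the assay

In an assay on U-937 cells for inhibition of Fatty-acid amide hydrolase 1 (Homo sapiens), read by scintillation counting, with a stated time of 15 min (a lower number here means a stronger inhibitor, a higher number a weaker inhibitor), compound 2 gives no number, only the limit > 10000 nM. The same holds across the set, since all values sit at the limit of > 10000 nM in this assay, at which 3 of the 3 values shown sit; compound 2 therefore cannot be placed above or below compound 1 or compound 3, and no ordering among the three exists.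

Compound 4 `Cc1c(-c2ccccc2)cc(C(=O)NC2CCCCCC2)c(=O)n1Cc1ccc(F)cc1` is the next member. Relative to compound 2 the change is phenyl in place of hydrogen on an aromatic carbon. For the measured compounds named here, no measured pair in the set isolates this change, so the size of the step is open. With compound 2 at a limit, any step toward stronger inhibition would only show once the number comes below that limit; the expected step is an at least 1.6-fold lower number from compound 2 to compound 4 (0.22 log units; that floor lies within the scatter), modest at best. Compound 4 is expected near 6000 nM, within 1500 nM to 20000 nM.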

Compound 4, half-maximal inhibitory concentration: 560 nM
For compound 4 the middle estimate is 11-fold (1.03 log units) above the measured one; measured number outside the range, below it.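

In this assay, phenyl in place of hydrogen on an aromatic carbon, ortho to a methyl group, gives an at least 17-fold lower number from compound 2 to compound 4 (1.25 log units; beyond the scatter). From the compounds shown here alone, compound 2 stands at a limit, so that step is a floor and its true size stays open. Compound 4, at 560 nM, is the only compound shown with a number, which makes this position the first place in the series where a change registers: the limit of > 10000 nM in this assay, at which 3 of the 4 values shown sit.

Open, going by these compounds, is whether an amine or a carboxylic acid on the phenyl, or a methyl in its place, would keep this gain. Also open, on these data alone, is whether the gain holds without the cycloheptylcarbamoyl group.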